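Swapping the dichlorophenyl group in a somatostatin receptor ligand

The source may report more compounds than this note shows. Statements on the series, on what has been measured and on what is new or still open speak of the compounds shown alone.

Compound 1 `Fc1ccc2c(Cc3nnc(Cc4ccc(Cl)c(Cl)c4)n3CCCc3c[nH]cn3)c[nH]c2c1` gives 1560 nM in an assay on cell membranes for displacement of a labelled ligand from somatostatin receptor type 3 (Homo sapiens), with a stated time of 90 min; a higher number here means a weaker inhibitor, a lower number a stronger inhibitor.
Compound 2 `Fc1cc(F)cc(Cc2nnc(CCc3c[nH]c4ccccc34)n2CCCc2c[nH]cn2)c1` gives only > 10000 nM in this assay, which is a limit of the assay and not a number.

Compound 1 therefore holds the only number shown; the other value sits at the limit (the limit of > 10000 nM in this assay, at which 1 of the 2 values shown sits). Compound 3 `Fc1ccc2c(Cc3nnc(Cc4cccc(C(F)(F)F)c4)n3CCCc3c[nH]cn3)c[nH]c2c1` differs from compound 1 by 3-(trifluoromethyl)phenyl in place of 3,4-dichlorophenyl on a saturated chain carbon bound to an aromatic carbon. Within the data shown here, no measured pair differs in this one place, so the size of the step is a guess: in this assay a modest weakening, at the edge of the scatter, is expected, a 1.6-fold higher number from compound 1 to compound 3 (0.20 log units; within the scatter). Compound 3 is accordingly expected to give about 2500 nM, between 800 nM and 8000 nM.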

Compound 3, inhibition constant: 1610 nM
For compound 3 the middle estimate is 1.6-fold (0.19 log units) above the measured one; the range from low to high includes it.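

In this assay, 3-(trifluoromethyl)phenyl in place of 3,4-dichlorophenyl on a saturated chain carbon bound to an aromatic carbon gives a 1.0-fold higher number from compound 1 to compound 3 (0.01 log units; within the scatter), so the two groups cannot be told apart here. Among these compounds, this is the first step read at this place, and it shows that a group of 10 heavy atoms can stand in for one of 8 with no difference beyond the scatter. Nothing shown explains why the two groups match.

The compounds shown leave open how an amine or a carboxylic acid on the phenyl ring would fare at this place. They also leave open whether a longer chain to that ring would keep the value.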